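From Fluorobenzyl to Methoxyphenyl on the Amide Nitrogen

The compounds below may be only part of what the source reports. "The series", "measured", "known", "first", "only" and "open" are said of these compounds alone.

Going by the values given here, compound 2 `COc1ccc2c(=O)c(/C=C/C(=O)NCc3ccc(F)cc3)coc2c1` gives 133000 nM in an ADME assay on HepG2 2.2.15 cells (Homo sapiens) for cytotoxicity, read by MTT assay, with stated times of 48 h and 9 days (a higher number here means that more compound is tolerated, a lower number that less compound is tolerated), the lowest of the three numbers measured so far. Compound 1 `O=C(/C=C/c1coc2cc(O)ccc2c1=O)NCc1ccc(F)cc1` gives 357000 nM, and compound 3 `O=C(/C=C/c1coc2cc(O)ccc2c1=O)Nc1ccccc1` gives 821000 nM. The methyl-for-hydrogen step a 2.7-fold lower number from compound 1 to compound 2 (0.43 log units; beyond the scatter) is modest but beyond the scatter, as is the exchange on the amide nitrogen in a 2.3-fold higher number from compound 1 to compound 3 (0.36 log units; beyond the scatter). Compound 4 `COc1ccc2c(=O)c(/C=C/C(=O)Nc3ccccc3OC)coc2c1` is not yet measured; compared with compound 2 the change is 2-methoxyphenyl in place of 4-fluorobenzyl on an amide-type nitrogen. The step from compound 1 to compound 3 bears on this one, since it also replaces 4-fluorobenzyl on the amide nitrogen, there by phenyl; it was modest and upward. Among the compounds with values here, the 2-methoxyphenyl itself appears in no measured compound, so that part of the change adds uncertainty rather than direction. Compound 4 is therefore expected to be tolerated at a somewhat higher concentration than compound 2. The expected step is a 1.9-fold higher number from compound 2 to compound 4 (0.27 log units; within the scatter). The estimate for compound 4 in this assay is 250000 nM, with a range from 100000 nM to 600000 nM.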

Compound 4, half-maximal cytotoxic concentration: 1050000 nM
Compound 4: the middle estimate sits 4.2-fold (0.62 log units) below what was measured; the measured number lies above the stated range.
By their numbers in this assay, from the lowest: compound 2; then compound 1; then compounds 3 and 4 (each within the scatter of the next).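

In this assay, going by these compounds alone, the exchange on the amide-type nitrogen gives a 7.9-fold higher number from compound 2 to compound 4 (0.90 log units; beyond the scatter), so an upward move at this position is no longer seen only with phenyl on the core of compound 1 but also with 2-methoxyphenyl on the core of compound 2. Among the compounds shown, both exchanges that put an aromatic ring in place of 4-fluorobenzyl raise the number, and none goes against this, although the entering group brings one hydrogen-bond acceptor and 4-fluorobenzyl brought none. No available evidence accounts for the size or direction of this step.

The compounds shown do not separate what the loss of 4-fluorobenzyl contributes from what the methoxy group on the entering ring contributes. They also leave open whether the number keeps rising with an aminophenyl group or a longer chain such as phenethyl on this nitrogen.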